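This account rests on a few compounds, and the source may have more. Where it says the series, first, only, none or still open, it means among the compounds named here.

Compound 1 `CC(C)(C)c1cc(NC(=O)[C@@H]2CCCCN2C(=O)c2ccc(Cl)cc2)no1`, compound 2 `CC(C)(C)c1cc(NC(=O)[C@@H]2CCCCN2C(=O)C2CCOCC2)no1` and the unmeasured compound 3 `CC(C)(C)c1cc(NC(=O)[C@@H]2CCCCN2C(=O)N2CCCCC2)no1` share one core. In an ADME assay (liver) for metabolic stability, with Liver microsome (Homo sapiens) as the target, read by LC-MS, using microsomes and NADPH, tested at 1 uM (on this read-out higher numbers stand for a longer-lived compound and lower numbers for a shorter-lived compound), compound 1 gives 1.25 h. Compound 2 is reported only at a limit of the assay, > 2 h, the one noted in the limit of > 2 h in this assay, at which 1 of the 2 values shown sits. Among the compounds with values here, the single measured step, an at least 1.6-fold higher number from compound 1 to compound 2 (0.20 log units; that floor lies within the scatter), is therefore bounded from below only. Compound 3 differs from compound 2 in that (piperidin-1-yl in place of oxan-4-yl on a carbonyl carbon). Within the data shown here, no measured step covers such a change, so compound 3 is expected to stay near the limit, with a step that the limit leaves unreadable from compound 2 to compound 3. The estimate for compound 3 is 2.5 h, between 1.2 h and 5 h.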

Compound 3, half-life: 0.233 h
The estimate for compound 3 lay 11-fold (1.03 log units) above the measured number; measured number below the stated range.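

On a carbonyl carbon whose other neighbour is an amide-type nitrogen in a ring, this assay proves sensitive to the group carried: piperidin-1-yl in place of oxan-4-yl gives an at least 8.5-fold lower number from compound 2 to compound 3 (0.93 log units; beyond the scatter), though both groups are six-membered non-aromatic rings. Piperidin-1-yl in place of 4-chlorophenyl also gives a 5.4-fold lower number from compound 1 to compound 3 (0.73 log units; beyond the scatter), leaving compound 3 with the lowest number of the three. The first step is only a floor, as compound 2 stands at a limit: the limit of > 2 h in this assay, at which 1 of the 3 values shown sits.

From the compounds shown here alone, it remains open how far compound 2 lies beyond that limit. Going by these compounds, it is also open whether a morpholin-4-yl or a dimethylamino group on the same carbonyl carbon would give a number as low as that of compound 3.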